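The compounds below may be only part of what the source reports. "The series", "measured", "known", "first", "only" and "open" are said of these compounds alone.

Measured compounds:
compound 1 `O=c1cc(CSc2nc3ccccc3s2)oc2ccc(Cl)cc12` gives > 25000 nM
compound 2 `Cc1ccc2oc(CSc3nc4nc(C)cc(C)n4n3)cc(=O)c2c1` gives > 25000 nM
compound 3 `Cc1cc(C)n2nc(SCc3cc(=O)c4cc(Cl)ccc4o3)nc2n1` gives > 25000 nM

All three compounds were tested in a functional assay on HEp-2 cells (Homo sapiens) for cytotoxicity, read by MTT assay, with a stated time of 72 h; on this read-out higher numbers stand for weaker inhibition and lower numbers for stronger inhibition. For compound 1 the value > 25000 nM is a limit of this assay and not a number. For compound 2 the value > 25000 nM is likewise a limit. For compound 3 the value > 25000 nM is a limit as well, so that all three results sit at the limit of > 25000 nM in this assay, at which 3 of the 3 values shown sit.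

Compound 2 and compound 3 differ in one place: methyl in place of chloro on an aromatic carbon. As far as these compounds go, both values being limits, the step that the two limits leave unreadable from compound 3 to compound 2 cannot be read, and its size remains unknown.

The unmeasured compound 4 `Cc1ccc2oc(CSc3nc4ccccc4s3)cc(=O)c2c1` stands to compound 1 as compound 2 stands to compound 3. The change from compound 1 to compound 4 is methyl in place of chloro on an aromatic carbon, the same change as that from compound 3 to compound 2, at the same place. How the core of compound 1 differs from the core of compound 3 is not broken down here.

Since compound 1 gives > 25000 nM and the matching change left compound 2 at a limit, compound 4 is expected to stay at a limit in this assay too, and the expected step that the limit leaves unreadable from compound 1 to compound 4 is estimated as small. Compound 4 is therefore estimated at 40000 nM, expected between 25000 nM and 120000 nM, most likely reported only as a limit.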

Compound 4, half-maximal inhibitory concentration: > 25000 nM
Compound 4 gave a limit, no number; the forecaster's own chance of this, stated with the estimate: 85%; the middle value does not contradict the limit.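

In this assay compound 4 gives > 25000 nM, which is a limit and not a number. Compound 1 also stands at a limit, so no new step can be read between compound 1 and compound 4. The compounds shown leave open how strongly any of them inhibits in this read-out, because every result stands at one limit: the limit of > 25000 nM in this assay, at which 4 of the 4 values shown sit.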